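Working notes: amine swap on the side chain

The source may hold more compounds than are shown below. What is called first, only, known or untested is meant among the compounds shown, and "the series" means these compounds.

- Compound 1 `Cc1cc(Cl)cc2c(=O)cc(-c3ccccc3Cl)oc12` in a functional assay on HepG2 cells (Homo sapiens) for cytotoxicity, read by MTT assay, with a stated time of 48 h (a lower number here means a stronger inhibitor, a higher number a weaker inhibitor), gives "not determined" (no result reported) as its entry
- Compound 2 `CCN(CC)Cc1cc(Cl)cc2c(=O)cc(-c3ccccc3Cl)oc12` in this assay gives 7940 nM as its value

Within the data shown here, compound 2 holds the only number, so it has no measured neighbour to rank against. Compound 3 `O=c1cc(-c2ccccc2Cl)oc2c(CN3CCCCC3)cc(Cl)cc12` carries piperidin-1-yl in place of diethylamino on a saturated chain carbon bound to an aromatic carbon. Among the measured compounds shown here, no measured step bears on this change, so nothing beyond the scatter is expected in this assay, in either direction. The estimated move is a 1.1-fold lower number from compound 2 to compound 3 (0.05 log units; within the scatter) and no more. Compound 3 is expected at (7000 nM), with an estimated range from (3000 nM) to (16000 nM).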

Compound 3, half-maximal inhibitory concentration: 10700 nM
Compound 3: the middle estimate sits 1.5-fold (0.18 log units) below what was measured; the measured number falls inside the stated range.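

Piperidin-1-yl in place of diethylamino on a saturated chain carbon bound to an aromatic carbon gives a 1.3-fold higher number from compound 2 to compound 3 (0.13 log units; within the scatter) in this assay. This first measured step at this place shows that, for this pair, the ring and the open-chain amine cannot be told apart in this read-out. No independent measurement bears on the result.

As far as these compounds go, it remains open whether morpholin-4-yl or a primary amine at this place would give a step beyond the scatter. From the compounds shown here alone, the effect of a longer chain between the amine and the shared core also remains open.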